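The source may hold more compounds than are shown below. What is called first, only, known or untested is meant among the compounds shown, and "the series" means these compounds.

In a functional assay on RD cells (Homo sapiens) for inhibition, read by luminescence and ATP content, with a stated time of 72 h (a higher number here means that more compound is tolerated, a lower number that less compound is tolerated), compound 1 `CCCCc1ccc(-c2ccc3ncc(-c4noc(C(F)(F)F)n4)cc3c2)cc1` gives > 7400 nM, which is a limit. Compound 2 `Cc1ccc(-c2ccc3ncc(-c4noc(C(F)(F)F)n4)cc3c2)cc1` gives > 22200 nM, also a limit. Compound 3 `CC(C)c1ccc(-c2ccc3ncc(-c4noc(C(F)(F)F)n4)cc3c2)cc1` gives > 200000 nM, again a limit. Compound 2 therefore stands at a limit and has no number of its own. Compound 4 `Cc1ccc(-c2ccc3ncc(-c4noc(C)n4)cc3c2)cc1` differs from compound 2 as follows: methyl in place of trifluoromethyl on an aromatic carbon. For the measured compounds named here, no measured step touches this place, and none has a readable size: a step that the two limits leave unreadable from compound 1 to compound 2, a step that the two limits leave unreadable from compound 1 to compound 3, a step that the two limits leave unreadable from compound 2 to compound 3. Going by the values given here, no step of definite size or direction can thus be expected in this assay. The estimated step is a step that the limit leaves unreadable from compound 2 to compound 4. Compound 4 is expected at about 30000 nM, with an estimated range of 8000 nM to 200000 nM.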

Compound 4, half-maximal cytotoxic concentration: > 7400 nM
Compound 4 ended at the assay's limit; the forecaster's own chance of this, stated with the estimate: 75%; the middle value does not contradict the limit.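

For the compounds shown here, compound 4 gives > 7400 nM in this assay, which is a limit; compound 2 also stands at a limit, so no step between them can be read. The compounds shown leave open where any actual half-maximal cytotoxic concentration lies, and whether methyl in place of trifluoromethyl changes it.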